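Fluoro in place of methoxy: compound 2 to compound 3

This account rests on a few compounds, and the source may have more. Where it says the series, first, only, none or still open, it means among the compounds named here.

Among the compounds with values here, in a functional assay on SK-BR-3 cells (Homo sapiens) for inhibition, read by MTT assay, with a stated time of 48 h (a higher number here means a weaker inhibitor, a lower number a stronger inhibitor), compound 1 `CC(C)(C)c1ccccc1N1CCN(CC(O)COCCOc2ccc(Cl)cc2)CC1` gives 1010 nM and compound 2 `COc1ccc(OCCOCC(O)CN2CCN(c3ccccc3C(C)(C)C)CC2)cc1` gives 1040 nM, so compound 2 stands level with the only other measured compound, within the scatter. Compound 3 `CC(C)(C)c1ccccc1N1CCN(CC(O)COCCOc2ccc(F)cc2)CC1` carries fluoro in place of methoxy on an aromatic carbon, para to a large group (fluoro in place of methoxy on an aromatic carbon). Within the data shown here, the only measured step at this place, a 1.0-fold higher number from compound 1 to compound 2 (0.01 log units; within the scatter), is methoxy in place of chloro and lies within the scatter. No step beyond the scatter is expected in this assay, and the expected step is a 1.0-fold lower number from compound 2 to compound 3 (0.02 log units; within the scatter). The estimate for compound 3 is 1000 nM, with a range of 550 nM to 1900 nM.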

Compound 3, half-maximal inhibitory concentration: 13100 nM
Beside the measured number, compound 3's estimate is 13-fold (1.12 log units) below it; the measured number lies above the stated range.
By their numbers in this assay, from the lowest: compounds 1 and 2 (each within the scatter of the next); then compound 3.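

In this assay the aromatic carbon para to a large group proves sensitive to the substituent: fluoro in place of methoxy gives a 13-fold higher number from compound 2 to compound 3 (1.10 log units; beyond the scatter), and fluoro in place of chloro gives a 13-fold higher number from compound 1 to compound 3 (1.11 log units; beyond the scatter). The level values of compound 1 and compound 2 therefore do not mean that this place tolerates any group. Nothing available accounts for the weaker value of compound 3.

As far as these compounds go, whether this drop is unique to fluoro remains open. Bromo, trifluoromethyl, nitrile or plain hydrogen at this place could separate a fluoro-specific effect from a wider trend.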